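Compound 2 Gains a ((4-methylphenyl)sulfonyl)amino Group

The compounds below may be only part of what the source reports. "The series", "measured", "known", "first", "only" and "open" are said of these compounds alone.

Measured so far in a functional assay on HepG2 cells (Homo sapiens) for antiproliferative activity, read by MTT assay, with a stated time of 48 h; on this read-out higher numbers stand for weaker inhibition and lower numbers for stronger inhibition:
- compound 1 `COc1ccc(CN(C(=O)Cn2cc(COc3ccccc3)nn2)c2cc(OC)c(OC)c(OC)c2)cc1`: 20500 nM
- compound 2 `COc1ccc(CN(C(=O)Cn2cc(CSC3=NCCS3)nn2)c2cc(OC)c(OC)c(OC)c2)cc1`: 25000 nM

Within the data shown here, compound 2 stands within the usual scatter of compound 1, its only measured neighbour. Compound 3 `COc1ccc(CN(C(=O)Cn2cc(CNS(=O)(=O)c3ccc(C)cc3)nn2)c2cc(OC)c(OC)c(OC)c2)cc1` differs from compound 2 in one place: a group of 11 heavy atoms (7 carbon, 1 nitrogen, 2 oxygen, 1 sulfur; one six-membered aromatic ring of carbon only) in place of a group of 6 heavy atoms (3 carbon, 1 nitrogen, 2 sulfur; one five-membered non-aromatic ring with 2 hetero atoms), on a saturated chain carbon bound to an aromatic carbon. Among the measured compounds shown here, one measured step bears on this change. That step, a 1.2-fold higher number from compound 1 to compound 2 (0.09 log units; within the scatter), exchanged a group on the same saturated chain carbon and stayed within the scatter. One small step says little about a new group, so no change beyond the scatter is expected in this assay. The expected size is a 1.3-fold lower number from compound 2 to compound 3 (0.10 log units; within the scatter). For compound 3 the estimated value is 20000 nM, within an expected range of 7000 nM to 55000 nM.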

Compound 3, half-maximal inhibitory concentration: 30500 nM
Estimate against measurement, compound 3: 1.5-fold (0.18 log units) below; the range from low to high includes it.
By their numbers in this assay, from the lowest: compounds 1, 2 and 3 (each within the scatter of the next).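

In this assay, the ((4-methylphenyl)sulfonyl)amino group gives a 1.2-fold higher number from compound 2 to compound 3 (0.09 log units; within the scatter), and in place of phenoxy it gives a 1.5-fold higher number from compound 1 to compound 3 (0.17 log units; within the scatter). Both steps stay within the scatter, so a third group, this one with a hydrogen-bond donor and a sulfonyl link, also gives a number within the scatter at this saturated chain carbon. Nothing measured here offers an explanation for this result.

As far as these compounds go, whether an amine or a carboxylic acid on this same carbon would give a number beyond the scatter remains open. Whether any group here can do so also remains unanswered.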